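A Hydroxy Step Carried Across Two Related Cores

A few compounds are considered here, and "the series" means these few. Any claim that something is new, unique, unknown or untested is made for them only; others in the source may bear on it.

Compound 1 `COc1cc2c(/C=C3/C(=O)N(C)c4ccccc43)c(Cl)n(C)c2cc1C` gives 10200 nM in a functional assay on cells (Cancer cell lines, Homo sapiens) for inhibition, with a stated time of 48 h; a higher number here means a weaker inhibitor of growth, a lower number a stronger inhibitor of growth. Compound 2 `COc1cc2c(/C=C3/C(=O)N(C)c4ccc(O)cc43)c(Cl)n(C)c2cc1C` gives 4270 nM in this assay. The change between them is hydroxy in place of hydrogen on an aromatic carbon and it made the step of a 2.4-fold lower number from compound 1 to compound 2 (0.38 log units; beyond the scatter). Compound 3 `COc1cc2c(/C=C3/C(=O)N(C)c4ccccc43)c[nH]c2cc1C` carries a different core; how the two cores differ is not broken down here. In this assay compound 3 gives 60300 nM, the highest number of the three measured compounds. Compound 4 `COc1cc2c(/C=C3/C(=O)N(C)c4ccc(O)cc43)c[nH]c2cc1C` is made from compound 3 by the change (hydroxy in place of hydrogen on an aromatic carbon), the same change as that from compound 1 to compound 2, at a place described in identical words. For compound 4 a step of a 2.4-fold lower number from compound 3 to compound 4 (0.38 log units; beyond the scatter) is expected, because the same change gave a 2.4-fold lower number from compound 1 to compound 2 (0.38 log units; beyond the scatter). Compound 4 is therefore estimated at 25000 nM, with a likely range from 10000 nM to 60000 nM.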

Compound 4, concentration for total growth inhibition: 28200 nM
Compound 4: middle estimate off by 1.1-fold (0.05 log units), on the low side; the range from low to high includes it.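

In this assay, hydroxy in place of hydrogen on an aromatic carbon gave a 2.1-fold lower number from compound 3 to compound 4 (0.33 log units; beyond the scatter) on the second core, in the same direction as on the first. The two steps agree: the same change on two cores in this assay, a 2.4-fold lower number (0.38 log units; beyond the scatter) from compound 1 to compound 2 and a 2.1-fold lower number (0.33 log units; beyond the scatter) from compound 3 to compound 4, 1.1-fold (0.05 log units) apart, within the scatter of two such steps. This shows that, for these two pairs, the step carried from one core to the other with its size unchanged within the scatter, but two pairs make no rule for the series and do not show why the number falls.

The compounds shown leave open whether an amine or a carboxylic acid at that place would also give matching steps on both cores. They also leave open whether the agreement would hold on a third core.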